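Swapping 4-chlorophenyl for cyclopropylamino on the shared core

The compounds below may be only part of what the source reports. "The series", "measured", "known", "first", "only" and "open" are said of these compounds alone.

Measured in a functional assay on MOLT-4 cells (Homo sapiens); on this read-out higher numbers stand for weaker inhibition and lower numbers for stronger inhibition:
Compound 1 `COc1ncnc2c1ncn2C[C@@H]1C[C@H](CO)c2ccccc21`: 24 ug/mL
Compound 2 `CC(C)Nc1ncnc2c1ncn2C[C@@H]1C[C@H](CO)c2ccccc21`: 24 ug/mL
Compound 3 `OC[C@H]1C[C@@H](Cn2cnc3c(-c4ccc(Cl)cc4)ncnc32)c2ccccc21`: 0.63 ug/mL

Compound 3 has the lowest number of the three, and its gaps to both others lie beyond the scatter. Compound 4 `OC[C@H]1C[C@@H](Cn2cnc3c(NC4CC4)ncnc32)c2ccccc21`, not yet measured, carries cyclopropylamino in place of 4-chlorophenyl on an aromatic carbon. For the measured compounds named here, the closest precedent is the opposite exchange, a 38-fold lower number from compound 2 to compound 3 (1.58 log units; beyond the scatter), with 4-chlorophenyl replacing isopropylamino. The exchange for methoxy, a 38-fold lower number from compound 1 to compound 3 (1.58 log units; beyond the scatter), is equally large, while no change at the digits printed from compound 1 to compound 2 (within the scatter) separates neither small substituent. A large upward step in this assay is therefore expected, back toward compound 2 at 24 ug/mL. The expected change is a 32-fold higher number from compound 3 to compound 4 (1.50 log units; beyond the scatter). Compound 4 is estimated at 20 ug/mL, within a range of 7 ug/mL to 50 ug/mL.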

Compound 4, half-maximal inhibitory concentration: 24 ug/mL
Beside the measured number, compound 4's estimate is 1.2-fold (0.08 log units) below it; the measured number falls inside the stated range.
By their numbers in this assay, from the lowest: compound 3; then compounds 1, 2 and 4 (each within the scatter of the next).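

In this assay, cyclopropylamino on this aromatic carbon does not keep what 4-chlorophenyl gave, with a 38-fold higher number from compound 3 to compound 4 (1.58 log units; beyond the scatter). A carbon ring on the amine nitrogen makes no difference against the open isopropyl group, with no change at the digits printed from compound 2 to compound 4 (within the scatter), and the exchange for methoxy likewise shows no change at the digits printed from compound 1 to compound 4 (within the scatter), so among these four compounds only compound 3 stands apart. Nothing available explains this separation.

The compounds shown leave open whether an unsubstituted phenyl would match compound 3 or whether the chlorine is required. From the compounds shown here alone, how a morpholine or a pyridine at this carbon would read also remains open.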